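The source may hold more compounds than are shown below. What is called first, only, known or untested is meant among the compounds shown, and "the series" means these compounds.

Compound 1 `COc1ccc(CN(C(=O)CSC(=S)N2CCc3ccccc32)c2cc(OC)c(OC)c(OC)c2)cc1` gives 6940 nM in a functional assay on KYSE-450 cells (Homo sapiens) for inhibition, read by CCK-8 assay, with a stated time of 48 h; on this read-out lower numbers stand for stronger inhibition and higher numbers for weaker inhibition. Compound 2 `COc1ccc(CN(C(=O)CSC(=S)N2CCc3cc(Br)ccc32)c2cc(OC)c(OC)c(OC)c2)cc1` reaches only the limit > 20000 nM in this assay. Compound 3 `COc1ccc(CN(C(=O)CSC(=S)N2CCN(C(=O)OC(C)(C)C)CC2)c2ccc(Br)cc2)cc1` likewise stops at the limit > 20000 nM in this assay. Going by these compounds, the step of an at least 2.8-fold lower number from compound 2 to compound 1 (0.45 log units; beyond the scatter) goes with the change (hydrogen in place of bromo on an aromatic carbon); its true size stays open because the limit of > 20000 nM in this assay, at which 2 of the 3 values shown sit, holds the starting value. Compound 4 `COc1ccc(CN(C(=O)CSC(=S)N2CCN(C(=O)OC(C)(C)C)CC2)c2ccccc2)cc1` awaits measurement in this assay. It carries the same kind of change from compound 3, (hydrogen in place of bromo on an aromatic carbon), but at a six-membered aromatic ring of carbon only, para to a large group, rather than a ring in a fused or bridged system of two rings, meta and para to a fused ring. The difference between the cores of compound 3 and compound 2 is not broken down here. A step of an at least 2.0-fold lower number from compound 3 to compound 4 (0.30 log units; that floor lies within the scatter) is expected because the matching change gave an at least 2.8-fold lower number from compound 2 to compound 1 (0.45 log units; beyond the scatter), and the differing surroundings widen the uncertainty. For compound 4 the estimated value is 10000 nM, between 4000 nM and 30000 nM.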

Compound 4, half-maximal inhibitory concentration: > 20000 nM
Compound 4: a limit, no number; the forecaster's own chance of this, stated with the estimate: 40%; middle value at least 2.0-fold (0.30 log units) from the limit.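

Going by these compounds alone, compound 3 and compound 4 both stop at a limit, so no step between them can be read: the limit of > 20000 nM in this assay, at which 3 of the 4 values shown sit. Still open, going by these compounds, is whether going from 4-bromophenyl to phenyl changes the read-out at all on the core of compound 3.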